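The source may report more compounds than this note shows. Statements on the series, on what has been measured and on what is new or still open speak of the compounds shown alone.

Compound 1 `CCCN(Cc1ccc(OCCN2C(=O)CCC2=O)c(C)c1)C(CC(=O)O)c1ccc(Cl)cc1`: 10.2 nm/s
Compound 2 `CCCN(Cc1ccc(OCCN2C(=O)CCC2=O)c(C)c1)[C@H](CC(=O)O)c1ccc(Cl)cc1`: "not determined" (no result reported)

Among the measured compounds shown here, in an ADME assay on Caco-2 cells (Homo sapiens) for permeability, read by LC-MS, with a stated time of 2 h (on this read-out lower numbers stand for lower permeability and higher numbers for higher permeability), compound 1 gives 10.2 nm/s, and this is the only number available. Compound 1 therefore cannot yet be ranked as high or low against a related compound. Compound 2 has the same atoms and connections, and the only distinction is in how the two are drawn (the fact that one of compounds 1 and 2 is drawn with a defined configuration and the other without, at the place where they differ). For the measured compounds named here, with no result for compound 2, there is no measured step to act as a guide.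

The next compound to be tested is compound 3 `CCN(Cc1ccc(OCCN2C(=O)CCC2=O)c(C)c1)C(CC(=O)O)c1ccc(Cl)cc1`. It has hydrogen in place of methyl on a saturated chain carbon, two bonds along the chain from an amine nitrogen, so the propyl group becomes ethyl (hydrogen in place of methyl on a saturated chain carbon, two bonds along the chain from an amine nitrogen). The rest of the structure stays the same.

This is a small edit, and no measurement shows how this assay responds to it, so no change beyond the usual scatter is expected. The estimate means a 1.1-fold lower number from compound 1 to compound 3 (0.03 log units; within the scatter), an expected step that stays within that scatter. For compound 3 the expected value is 9.5 nm/s, with an estimated range from 4.5 nm/s to 20 nm/s.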

Compound 3, apparent permeability: 3.9 nm/s
The estimate for compound 3 lay 2.4-fold (0.39 log units) above the measured number; the measured number lies below the stated range.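

Among the compounds shown here, until now, this assay offered one number and no step, so nothing showed whether this part of the molecule had any bearing on the read-out. The propyl to ethyl change now gives a 2.6-fold lower number from compound 1 to compound 3 (0.42 log units; beyond the scatter), a modest step but one beyond the usual scatter, showing that the read-out responds at this position. The edit is small, with a single carbon leaving and no ring, hydrogen-bond donor, hydrogen-bond acceptor or net charge involved, yet nothing available here accounts for the size of the step.

Going by these compounds, a single step gives a direction for one edit only, so it remains open whether a longer chain such as butyl, a branched chain such as isopropyl, or a shorter methyl group would continue the same trend or break it. The step between compound 1 and compound 2 cannot be read, which also leaves open whether a defined configuration at that place makes any difference to the number.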